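Aryl exchange from compound 3 to compound 4

The source may report more compounds than this note shows. Statements on the series, on what has been measured and on what is new or still open speak of the compounds shown alone.

In a functional assay on DU-145 cells (Homo sapiens) for inhibition, read by trypan blue exclusion, with a stated time of 96 h (on this read-out lower numbers stand for stronger inhibition of growth and higher numbers for weaker inhibition of growth), compound 1 `Cc1ccc(CS/C(=C/c2cc(Cl)cc(Cl)c2)C(=O)c2ccc(Cl)cc2)cc1` gives 10000 nM, compound 2 `Cc1ccc(CS/C(=C/c2c[nH]c3ccc(Cl)cc23)C(=O)c2ccc(Cl)cc2)cc1` gives 1000 nM and compound 3 `Cc1ccc(CS/C(=C/c2cc([N+](=O)[O-])ccc2F)C(=O)c2ccc(Cl)cc2)cc1` gives 1000 nM. Compound 3 therefore stands level with compound 2, and the two share the low end of the three numbers.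

The next compound, compound 4 `Cc1ccc(CS/C(=C/c2ccccc2Br)C(=O)c2ccc(Cl)cc2)cc1`, differs from compound 3 at a single place, on a double-bonded chain carbon bound to a double-bonded chain carbon: 2-bromophenyl in place of 2-fluoro-5-nitrophenyl on a double-bonded chain carbon bound to a double-bonded chain carbon.

All three measured steps fall at that same place. Two are modest and beyond the scatter: a 10-fold lower number from compound 1 to compound 2 (1.00 log units; beyond the scatter) and a 10-fold lower number from compound 1 to compound 3 (1.00 log units; beyond the scatter). The third, no change at the digits printed from compound 2 to compound 3 (within the scatter), lies within the scatter. The group at this place has thus moved the number across the whole range seen so far, although three compounds make a thin basis. For the measured compounds named here, no measured compound carries 2-bromophenyl. Its closest counterpart is the halogen-only phenyl group of compound 1, at 10000 nM, so the expectation leans toward that end of the range without reaching it.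

An upward step of modest size is expected, a 3.0-fold higher number from compound 3 to compound 4 (0.48 log units; beyond the scatter). Compound 4 is expected at 3000 nM, with an estimated range of 1000 nM to 10000 nM.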

Compound 4, concentration for 50% growth inhibition: 10000 nM
Beside the measured number, compound 4's estimate is 3.3-fold (0.52 log units) below it; low and high end bracket the measured number.
By their numbers in this assay, from the lowest: compounds 2 and 3 (each within the scatter of the next); then compounds 1 and 4 (each within the scatter of the next).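

In this assay the change to 2-bromophenyl undoes the gain seen with the other two groups at this place, on a double-bonded chain carbon bound to a double-bonded chain carbon (a 10-fold higher number from compound 3 to compound 4 (1.00 log units; beyond the scatter); a 10-fold higher number from compound 2 to compound 4 (1.00 log units; beyond the scatter)), while the comparison with the other halogen-only phenyl group shows a flat result (no change at the digits printed from compound 1 to compound 4 (within the scatter)). Among these four compounds, the two halogen-only phenyl groups therefore share the high end and the 5-chloro-1H-indol-3-yl and 2-fluoro-5-nitrophenyl groups share the low end, and the different halogens and their different placing on the ring of compounds 1 and 4 leave no mark on the number. No measurement is available here that explains this split.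

As far as these compounds go, it remains open which part of 2-fluoro-5-nitrophenyl goes with the lower number, and whether a phenyl group carrying only a nitro group, or an amine or a carboxylic acid in its place, would fall with compounds 2 and 3 or with compounds 1 and 4. From the compounds shown here alone, all four compounds also share everything outside this place, so it is equally open whether the split holds when the 4-chlorophenyl ketone or the methylbenzyl sulfide part of the core changes.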